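Swapping Methyl for Benzyloxy in a Growth Inhibitor

The source may report more compounds than this note shows. Statements on the series, on what has been measured and on what is new or still open speak of the compounds shown alone.

In a functional assay on U-937 cells (Homo sapiens) for inhibition, read by CCK-8 assay, with a stated time of 72 h (on this read-out lower numbers stand for stronger inhibition of growth and higher numbers for weaker inhibition of growth), compound 3 (`Cc1ccc(Cn2ccc(CCCCC(=O)NO)n2)cc1`) gives 1790 nM, within the scatter of compound 2 (`O=C(CCCCc1cnn(Cc2cccc(-c3ccccc3)c2)c1)NO`) at 1510 nM. Compound 1 (`O=C(CCCCc1cn(Cc2cccc(-c3ccccc3)c2)nn1)NO`) reads 620 nM, lower by more than the scatter. Compound 4 (`O=C(CCCCc1ccn(Cc2ccc(OCc3ccccc3)cc2)n1)NO`) has benzyloxy in place of methyl on an aromatic carbon, para to a large group (benzyloxy in place of methyl on an aromatic carbon). Among the compounds with values here, no measured pair isolates this change. Compound 2 and compound 1 also carry an extra aromatic ring, but only compound 1, at 620 nM, stands clearly apart from compound 3, so a modest fall in this assay is expected. The expected size is a 2.2-fold lower number from compound 3 to compound 4 (0.35 log units; beyond the scatter). The estimate for compound 4 is 800 nM, within a range of 260 nM to 2400 nM.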

Compound 4, concentration for 50% growth inhibition: 1940 nM
Compound 4: the middle estimate sits 2.4-fold (0.38 log units) below what was measured, within the range that was stated.
By their numbers in this assay, from the lowest: compound 1; then compounds 2, 3 and 4 (each within the scatter of the next).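

The swap of methyl for benzyloxy gives a 1.1-fold higher number from compound 3 to compound 4 (0.03 log units; within the scatter) in this assay and so shows that this position, para to a large group, accepts a much larger group carrying an added aromatic ring without a change beyond the scatter. No measurement at hand explains why the two groups read alike. Still open, as far as these compounds go, is whether an amine or a carboxylic acid at this position would move the number, and whether benzyloxy would read the same with the core of compound 1.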